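The source may report more compounds than this note shows. Statements on the series, on what has been measured and on what is new or still open speak of the compounds shown alone.

Among the compounds with values here, in a functional assay on MIA PaCa-2 cells (Homo sapiens) for inhibition, read by MTT assay, with a stated time of 72 h (a lower number here means a stronger inhibitor, a higher number a weaker inhibitor), compound 2 `COc1cc(NC(C)CCCNC(=O)NNC(=O)Nc2ccc(Br)cc2)c2ncccc2c1` gives 231000 nM as the higher of the two numbers so far, while compound 1 `COc1cc(NC(C)CCCNC(=O)Nc2cccc(F)c2)c2ncccc2c1` gives 22000 nM for comparison. Compound 3 `COc1cc(NC(C)CCCNC(=O)Nc2cccc(O)c2)c2ncccc2c1` carries 3-hydroxyphenyl in place of ((4-bromophenyl)carbamoyl)amino on an amide-type nitrogen, with the difference counted as 3-hydroxyphenyl in place of ((4-bromophenyl)carbamoyl)amino on an amide-type nitrogen in full. Within the data shown here, one measured step bears on this change. The large step of an 11-fold higher number from compound 1 to compound 2 (1.02 log units; beyond the scatter) lies beyond the scatter and brought in the group that compound 3 gives up. Compound 3 again has a substituted phenyl on that nitrogen, as compound 1 does with 3-fluorophenyl, so a step of similar size towards a lower number is expected. Among the measured compounds shown here, no measured compound carries 3-hydroxyphenyl, which leaves the size uncertain. The expected change is a 7.7-fold lower number from compound 2 to compound 3 (0.89 log units; beyond the scatter) and is estimated to lie beyond the scatter. For compound 3 the estimated value is 30000 nM within an expected range of 12000 nM to 75000 nM in this series.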

Compound 3, half-maximal inhibitory concentration: 46000 nM
Beside the measured number, compound 3's estimate is 1.5-fold (0.19 log units) below it; low and high end bracket the measured number.
By their numbers in this assay, from the lowest: compound 1; then compound 3; then compound 2.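

In this assay, 3-hydroxyphenyl in place of ((4-bromophenyl)carbamoyl)amino on the amide-type nitrogen gives a 5.0-fold lower number from compound 2 to compound 3 (0.70 log units; beyond the scatter), so a directly attached substituted phenyl recovers part of the rise seen in an 11-fold higher number from compound 1 to compound 2 (1.02 log units; beyond the scatter). Hydroxy in place of fluoro on the aromatic carbon gives a 2.1-fold higher number from compound 1 to compound 3 (0.32 log units; beyond the scatter), the first reading of a change on the ring itself, and shows that the ring substituent alone moves the number modestly. No supporting data bear on the reason for either step.

Still open, from the compounds shown here alone, is how an amino group or a carboxylic acid on that aromatic carbon would compare with hydroxy and fluoro. Also open, going by these compounds, is whether 4-bromophenyl attached directly to the amide-type nitrogen would read closer to compound 1 or to compound 2.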